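A few compounds are considered here, and "the series" means these few. Any claim that something is new, unique, unknown or untested is made for them only; others in the source may bear on it.

Measured compounds:
- compound 1 `COc1cc(Cl)cc(-c2nn(-c3cccc(NC(=O)c4ccc(Cl)c(Cl)c4)c3)cc2-c2ccncc2)c1`: in a functional assay on SNB-19 cells (Homo sapiens) for inhibition, read by sulforhodamine B assay, with a stated time of 48 h, tested at 10 uM (on this read-out lower numbers stand for a stronger effect and higher numbers for a weaker effect at the one concentration tested), compound 1 gives 71.6%
- compound 2 `COc1cc(Cl)cc(-c2nn(-c3cccc(NC(=O)Nc4ccc(Cl)c(Cl)c4)c3)cc2-c2ccncc2)c1`: in this assay compound 2 gives 17.8%

Within the data shown here, compound 2 stands lowest of the two numbers in this assay, and its nearest neighbour, compound 1, lies a long way higher; the one measured step, a number 53.8 percentage points lower from compound 1 to compound 2 (beyond the scatter), is the change from the carbonyl-linked 3,4-dichlorophenyl of compound 1 to the (3,4-dichlorophenyl)amino of compound 2, and it is large and beyond the scatter.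

Compound 3 `COc1cc(Cl)cc(-c2nn(-c3cccc(NC(=O)Nc4cccc(C(F)(F)F)c4)c3)cc2-c2ccncc2)c1` keeps the linker of compound 2 and changes only the aryl group on the amide-type nitrogen: 3-(trifluoromethyl)phenyl in place of 3,4-dichlorophenyl on an amide-type nitrogen. Among the measured compounds shown here, no measured step bears on this kind of change; the only step, a number 53.8 percentage points lower from compound 1 to compound 2 (beyond the scatter), concerns the linker, not the aryl group, so it gives no direct guide. With the linker of compound 2 kept, compound 3 is expected to stay on the lower side of the two numbers, with a step of a number 12.2 percentage points higher from compound 2 to compound 3 (beyond the scatter) estimated, most likely a modest rise. For compound 3 the estimate in this assay is 30%, with a range from 12% to 60%.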

Compound 3, a percentage reported as activity, at one concentration (the size of the read-out at that concentration, not a potency): 16.1%
Compound 3: middle estimate off by 13.9 percentage points, on the high side, and the stated range covers the measured number.
By their numbers in this assay, from the lowest: compounds 3 and 2 (each within the scatter of the next); then compound 1.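

In this assay, replacing 3,4-dichlorophenyl with 3-(trifluoromethyl)phenyl on the amide-type nitrogen gives a number 1.7 percentage points lower from compound 2 to compound 3 (within the scatter), so this read-out does not separate these two aryl groups at this position, even though one carries two chlorine atoms and the other three fluorine atoms. The large linker step no longer rests on a single aryl group: alongside a number 53.8 percentage points lower from compound 1 to compound 2 (beyond the scatter), the series now has a number 55.5 percentage points lower from compound 1 to compound 3 (beyond the scatter), and both compounds with an arylamino group on the carbonyl carbon lie far from compound 1 in this assay. No measurement on hand accounts for either the large linker steps or the lack of separation between the two aryl groups.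

As far as these compounds go, it remains open whether this tolerance extends beyond these two substituted phenyl groups, for example to an unsubstituted phenyl, a pyridine, a carboxylic acid or a longer alkyl chain on the amide-type nitrogen. From the compounds shown here alone, it is also open whether the two compounds that cannot be told apart in this assay would stay together across a range of concentrations or in other cell lines, since the values shown come from one concentration in one cell line.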